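Cyanoguanidine Chain Variants in a Whole-Organism Assay

The compounds below may be only part of what the source reports. "The series", "measured", "known", "first", "only" and "open" are said of these compounds alone.

Measured compounds:
compound 1, `N#CNC(=N)NCCCCn1nc(-c2ccccc2)ccc1=O`, 61.2%
compound 2, `CN(C)/C(=N/CCCn1nc(-c2ccccc2)ccc1=O)NC#N`, 72.2%

In a functional assay on the whole organism with Rattus norvegicus as the target, at a dose of 100 mg/kg (on this read-out higher numbers stand for more inhibition at the one dose given (going by the name of the read-out) and lower numbers for less inhibition), compound 2 gives 72.2%, the highest of the two numbers; its nearest neighbour is compound 1, which gives 61.2%. Among the compounds with values here, the one step between them, a number 11 percentage points higher from compound 1 to compound 2 (beyond the scatter), is modest. Compound 3, `N#CNC(=N)NCCCn1nc(-c2ccccc2)ccc1=O`, has not yet been measured in this assay. It differs from compound 2 as follows: a group of 6 heavy atoms (2 carbon, 4 nitrogen; no ring) in place of a group of 8 heavy atoms (4 carbon, 4 nitrogen; no ring), on a saturated chain carbon, three bonds along the chain from an aromatic nitrogen. Within the data shown here, the entering group is the same group that compound 1 carries, on a chain one carbon shorter; since the only step that bears on this change is a number 11 percentage points higher from compound 1 to compound 2 (beyond the scatter), and it reversed part of what compound 3 now reverses, compound 3 is expected to give a number between the two measured values, nearer that of compound 1. The expected step is a number 11.2 percentage points lower from compound 2 to compound 3 (beyond the scatter). For compound 3 the estimate in this assay is 61%, in the range 44% to 78%.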

Compound 3, a percentage reported as inhibition, in the whole organism at one dose (the size of the read-out at that dose, not a potency): 33.3%
Compound 3: the middle estimate sits 27.7 percentage points above what was measured; measured number outside the range, below it.
By their numbers in this assay, from the lowest: compound 3; then compound 1; then compound 2.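

In this assay, the group of 6 heavy atoms gives the lowest number of the three at this place, with a number 38.9 percentage points lower from compound 2 to compound 3 (beyond the scatter) and a number 27.9 percentage points lower from compound 1 to compound 3 (beyond the scatter). Compounds 1 and 2 alone showed only a modest difference between two larger groups, whereas compound 3 shows that a change on this saturated chain carbon can move the read-out much further. The step from compound 2 is the larger of the two, so the group of 8 heavy atoms stands furthest from the group of 6 heavy atoms in this read-out. Nothing available here explains the drop.

The compounds shown leave open what a longer chain would give with the group of 8 heavy atoms, and whether a simple amine or a carboxylic acid at this place would hold the number up. They also leave open whether these differences persist at other doses, as each number comes from a single dose.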